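The source may report more compounds than this note shows. Statements on the series, on what has been measured and on what is new or still open speak of the compounds shown alone.

In an ADME assay on BHK-21 cells (Mesocricetus auratus) for cytotoxicity, read by MTT assay, with a stated time of 96 h (a higher number here means that more compound is tolerated, a lower number that less compound is tolerated), compound 1 `Cc1ccc(/N=N/N(C)c2ccccc2)cc1` gives > 100000 nM, which is a limit of the assay and not a number. Compound 2 `c1ccc(/N=N/N2CCN(c3ccccc3)CC2)cc1` gives > 100000 nM, again a limit. For the measured compounds named here, compound 3 `CN1CCN(/N=N/c2ccccc2)CC1` gives 70000 nM, the only true number so far, so its exact distance from the other two remains unknown.

Compound 4 `CCOC(=O)N1CCN(/N=N/c2ccccc2)CC1` differs from compound 3 by one change, ethoxycarbonyl in place of methyl on an amine nitrogen in a ring. Going by the values given here, only one measured step touches this same place: an at least 1.4-fold lower number from compound 2 to compound 3 (0.15 log units; that floor lies within the scatter), where methyl took the place of phenyl. Among the compounds with values here, that step is open-ended and gives only a floor, so it offers a weak guide to size, and no measured step involves ethoxycarbonyl itself. With so little to go on, no large shift in this assay is expected. The estimated change is a 1.2-fold higher number from compound 3 to compound 4 (0.08 log units; within the scatter), a small upward move that is expected to stay within the scatter. A result reported only as a limit would be no surprise. For compound 4 the expected value is 85000 nM, with an estimated range from 35000 nM to 150000 nM.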

Compound 4, half-maximal cytotoxic concentration: > 100000 nM
Compound 4 gave a limit, no number; the forecaster's own chance of this, stated with the estimate: 50%; middle value at least 1.1-fold (0.07 log units) away from the limit.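

Three groups have now been seen on this amine nitrogen in a ring, and in this assay only methyl gives a true number, while phenyl and ethoxycarbonyl both end at a limit. Replacing methyl with ethoxycarbonyl gives an at least 1.4-fold higher number from compound 3 to compound 4 (0.15 log units; that floor lies within the scatter), so this change can be read only as a floor, and that floor does not clear the usual scatter. The real size of the step stays hidden because compound 4 gives a limit of the assay and not a number: the limit of > 100000 nM in this assay, at which 3 of the 4 values shown sit.

Compound 2 and compound 4 both end at a limit, and the step between them cannot be read. Also open, from the compounds shown here alone, is how a carboxylic acid, a primary amine or a longer alkyl chain on this nitrogen would read in this assay.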